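Swapping tert-butyl for phenyl on the pyrazole-like core

The compounds below may be only part of what the source reports. "The series", "measured", "known", "first", "only" and "open" are said of these compounds alone.

Of the compounds shown here, three have been measured so far: compound 1 `CC(C)(C)c1cc(NC(=O)Nc2cc(C(F)(F)F)cc(C(F)(F)F)c2)n(-c2ccccc2)n1` with 0 degrees C, compound 2 `Cc1ccc(-n2nc(C(C)(C)C)cc2NC(=O)Nc2cc(C(F)(F)F)cc(C(F)(F)F)c2)cc1` with 0 degrees C, and compound 3 `Cn1nc(C(C)(C)C)cc1NC(=O)Nc1cc(C(F)(F)F)cc(C(F)(F)F)c1` with 2.4 degrees C in an assay on isolated protein for inhibition of STE20-like serine/threonine-protein kinase (Homo sapiens), read by thermal shift assay, tested at 10 uM; on this read-out lower numbers stand for weaker stabilisation of the target and higher numbers for stronger stabilisation of the target against heat.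

Compound 3 stands highest of the three numbers in this assay; its nearest neighbour is compound 1, and compound 2 lies as far away. The steps of a number 2.4 degrees C higher from compound 1 to compound 3 (beyond the scatter) and a number 2.4 degrees C higher from compound 2 to compound 3 (beyond the scatter) both came from changing the group on the aromatic nitrogen, while no change at the digits printed from compound 1 to compound 2 (within the scatter) shows that methyl for hydrogen on the aryl made no difference.

Compound 4 `Cn1nc(-c2ccccc2)cc1NC(=O)Nc1cc(C(F)(F)F)cc(C(F)(F)F)c1` differs from compound 3 in another place: phenyl in place of tert-butyl on an aromatic carbon. Within the data shown here, no measured step touches this position, so the measured steps give no direct guidance; they show only that changes elsewhere moved this assay modestly at most. A step of similar or smaller size, in either direction, is therefore expected, a number 0.90 degrees C lower from compound 3 to compound 4 (within the scatter). Compound 4 is expected to give about 1.5 degrees C, between -1 degrees C and 4 degrees C.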

Compound 4, shift of the target's melting temperature: 1.9 degrees C
Compound 4: middle estimate off by 0.40 degrees C, on the low side; low and high end bracket the measured number.
By their numbers in this assay, from the lowest: compounds 1 and 2 (each within the scatter of the next); then compounds 4 and 3 (each within the scatter of the next).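

In this assay, the aromatic carbon two ring bonds from the ring atom that bears a methyl group takes a change of group with a number 0.50 degrees C lower from compound 3 to compound 4 (within the scatter), as phenyl, with its six-membered aromatic ring, enters in place of tert-butyl. The earlier compounds shown here showed only a change on the aromatic nitrogen, where a number 2.4 degrees C higher from compound 1 to compound 3 (beyond the scatter) came with methyl in place of phenyl, so the number does not answer alike to every change of group on this core. No evidence is at hand on what lies behind this result.

Among the compounds shown, this carbon carries only tert-butyl or phenyl, so it remains open how an amine, a carboxylic acid or a longer chain there would read. Going by these compounds, it also remains open whether phenyl at this carbon would read the same with a group other than methyl on the aromatic nitrogen.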